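N-Methylation of the Piperazine in a Quinolone Series

The source may report more compounds than this note shows. Statements on the series, on what has been measured and on what is new or still open speak of the compounds shown alone.

Compound 1 `CCn1cc(-c2nc3ccccc3[nH]2)c(=O)c2cc(F)c(N3CCNCC3)cc21` carries the shared core with a piperazin-1-yl group. In a functional assay on HeLa cells (Homo sapiens) for cytotoxicity, read by sulforhodamine B assay, with a stated time of 48 h (on this read-out higher numbers stand for weaker inhibition of growth and lower numbers for stronger inhibition of growth), compound 1 gives only a limit, > 10000 nM. Compound 2 `CCn1cc(-c2nc3ccc(N)cc3[nH]2)c(=O)c2cc(F)c(N3CCNCC3)cc21` differs by an amino group on an aromatic carbon, and in this assay compound 2 likewise gives only a limit, > 10000 nM. The step that the two limits leave unreadable from compound 1 to compound 2 therefore cannot be sized, since both values sit at the limit of > 10000 nM in this assay, at which 2 of the 2 values shown sit. Compound 3 `CCn1cc(-c2nc3ccc(N)cc3[nH]2)c(=O)c2cc(F)c(N3CCN(C)CC3)cc21` differs from compound 2 by methyl in place of hydrogen on an amine nitrogen in a ring. For the measured compounds named here, no measured step speaks to this change, and compound 2 stands at the limit, so compound 3 is expected to remain near that limit, a step that the limit leaves unreadable from compound 2 to compound 3. Compound 3 is estimated at 12000 nM in this assay, within 4000 nM to 40000 nM.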

Compound 3, concentration for 50% growth inhibition: > 10000 nM
Compound 3 gave a limit, no number; the forecaster's own chance of this, stated with the estimate: 70%; the middle value does not contradict the limit.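

In this assay compound 3 also gives only a limit, > 10000 nM. For the compounds shown here, no step from compound 2 to compound 3 can be read, since the values shown all stand at one limit: the limit of > 10000 nM in this assay, at which 3 of the 3 values shown sit. The compounds shown leave open whether 4-methylpiperazin-1-yl and piperazin-1-yl differ at all in growth inhibition.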